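Replacing the 2-methylcyclohexyl group of compound 3

The source may hold more compounds than are shown below. What is called first, only, known or untested is meant among the compounds shown, and "the series" means these compounds.

In an in vitro ADME assay on microsomes from liver (Homo sapiens) for pharmacokinetics (a higher number here means faster removal of the compound, a lower number slower removal), compound 2 (`Cc1ccc(S(=O)(=O)N2C=CNC(=O)[C@H]2CC(=O)NC2CCCCC2)cc1`) gives 147 mL.min-1.g-1 and compound 3 (`Cc1ccc(S(=O)(=O)N2C=CNC(=O)[C@H]2CC(=O)NC2CCCCC2C)cc1`) gives 212 mL.min-1.g-1. The added methyl gives a 1.4-fold higher number from compound 2 to compound 3 (0.16 log units; within the scatter), so these two stand level at the top of the numbers for the series. Compound 1 (`Cc1ccc(S(=O)(=O)N2C=CNC(=O)[C@H]2CC(=O)NC2CCNc3ccccc32)cc1`) reports only a limit, < 50 mL.min-1.g-1.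

On the amide-type nitrogen, compound 4 (`Cc1ccc(S(=O)(=O)N2C=CNC(=O)[C@H]2CC(=O)N[C@H]2CCN(C)CC2(C)C)cc1`) carries a different group: a group of 9 heavy atoms (8 carbon, 1 nitrogen; one six-membered non-aromatic ring with 1 hetero atom) in place of a group of 7 heavy atoms (7 carbon; one six-membered non-aromatic ring of carbon only), on an amide-type nitrogen. Among the measured compounds shown here, the nearest guide is compound 1, the only measured compound with a hetero atom in the ring at this place. The steps from it are an at least 2.9-fold higher number from compound 1 to compound 2 (0.46 log units; beyond the scatter) and an at least 4.2-fold higher number from compound 1 to compound 3 (0.62 log units; beyond the scatter), and both are bounds. Compound 4 lacks the aromatic ring of compound 1, so the comparison is only partial. A modest step towards a lower number in this assay is therefore expected, opposite in direction to those two steps. The expected step is a 2.8-fold lower number from compound 3 to compound 4 (0.45 log units; beyond the scatter). Compound 4 is estimated at 75 mL.min-1.g-1, with an expected range of 30 mL.min-1.g-1 to 180 mL.min-1.g-1.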

Compound 4, intrinsic clearance in microsomes: < 14 mL.min-1.g-1
Compound 4: a limit, no number (the forecaster's own chance of this, stated with the estimate: 35%); middle value at least 5.3-fold (0.72 log units) away from the limit.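

On the amide-type nitrogen, the group entering in compound 4 gives an at least 15-fold lower number from compound 3 to compound 4 (1.18 log units; beyond the scatter) and an at least 10-fold lower number from compound 2 to compound 4 (1.02 log units; beyond the scatter) in this assay, so a low reading at this place does not depend on the aromatic ring that compound 1 carries. Compound 4 reports a limit, not a number: the limit of < 14 mL.min-1.g-1 in this assay, at which 1 of the 4 values shown sits. The step from compound 1 to compound 4 cannot be read, as compound 1 also reports a limit: the limit of < 50 mL.min-1.g-1 in this assay, at which 1 of the 4 values shown sits.

No comparison in one place among the compounds shown separates the ring hetero atom of compound 4 from the carbon groups on that ring, so which part of the entering group carries the change stays open. Also open, as far as these compounds go, is how a hydroxyl or a carboxylic acid on the 2-methylcyclohexyl group would read in this assay.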